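Extending the Side Chain of Compound 2

This account rests on a few compounds, and the source may have more. Where it says the series, first, only, none or still open, it means among the compounds named here.

In a functional assay on COLO 205 cells (Homo sapiens) for inhibition, read by MTT assay, with a stated time of 24 h (a lower number here means a stronger inhibitor, a higher number a weaker inhibitor), compound 2 `CCCc1cc2ccccc2nc1-c1cc(-c2ccccc2)no1` gives 48900 nM. Compound 1 `Fc1ccc(-c2cc(/C=N/c3ccccc3)on2)cc1` gives 33100 nM in this assay, and the two numbers lie within the usual scatter of each other, so compound 2 stands alongside compound 1 rather than apart from it. Compound 3 `CCCCCc1cc2ccccc2nc1-c1cc(-c2ccccc2)no1` differs from compound 2 by ethyl in place of hydrogen on a saturated chain carbon, three bonds along the chain from an aromatic carbon. Within the data shown here, no measured pair shows this change, so its effect is unknown here. The expected step is a 1.2-fold lower number from compound 2 to compound 3 (0.09 log units; within the scatter), a shift that stays within the scatter. Compound 3 is therefore expected to give about 40000 nM in this assay, with a range from 15000 nM to 110000 nM.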

Compound 3, half-maximal inhibitory concentration: > 100000 nM
Compound 3: no number, only a limit; the forecaster's own chance of this, stated with the estimate: 12%; at least 2.5-fold (0.39 log units) between middle value and limit.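

At this saturated chain carbon, three bonds along the chain from an aromatic carbon, ethyl in place of hydrogen turns propyl into pentyl and gives an at least 2.0-fold higher number from compound 2 to compound 3 (0.31 log units; beyond the scatter) in this assay, so the longer chain here weakens inhibition. Compound 3 gives no number, only a limit of the assay: the limit of > 100000 nM in this assay, at which 1 of the 3 values shown sits.

The compounds shown leave open how far the true value of compound 3 lies past that limit, and whether a butyl chain would stand with compound 2 or with compound 3. They also leave open how an amine at the end of the chain would read.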